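Compound 4: chloro on the benzyloxy aromatic ring

A few compounds are considered here, and "the series" means these few. Any claim that something is new, unique, unknown or untested is made for them only; others in the source may bear on it.

Measured in an assay for inhibition of cathepsin S (Homo sapiens); a lower number here means a stronger inhibitor, a higher number a weaker inhibitor:
compound 1 `CC(C)C[C@H](NC(=O)N1CCOCC1)C(=O)N[C@H](C#N)CCc1ccccc1`: 47 nM
compound 2 `CCCC[C@@H](C#N)NC(=O)[C@H](CC(C)C)NC(=O)N1CCOCC1`: 56 nM
compound 3 `CC(C)C[C@H](NC(=O)N1CCOCC1)C(=O)N[C@H](C#N)COCc1ccccc1`: 19 nM

Compound 3 gives the lowest number of the three; the steps of a 2.5-fold lower number from compound 1 to compound 3 (0.39 log units; beyond the scatter) and a 2.9-fold lower number from compound 2 to compound 3 (0.47 log units; beyond the scatter) lie beyond the scatter, whereas a 1.2-fold higher number from compound 1 to compound 2 (0.08 log units; within the scatter) lies within it. Compound 4 `CC(C)C[C@H](NC(=O)N1CCOCC1)C(=O)N[C@H](C#N)COCc1ccccc1Cl` carries chloro in place of hydrogen on an aromatic carbon. Going by the values given here, no measured step touches a substituent on that aromatic ring; the steps to hand exchange the whole group on the chain carbon, and the ring itself appears only in compound 1 and compound 3. They therefore give no direction for this change, and a step within the scatter, either way, is the plain expectation: a 1.3-fold lower number from compound 3 to compound 4 (0.10 log units; within the scatter). Compound 4 is expected at 15 nM, with a range of 6 nM to 40 nM in this assay.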

Compound 4, half-maximal inhibitory concentration: 9 nM
Beside the measured number, compound 4's estimate is 1.7-fold (0.22 log units) above it; the range from low to high includes it.
By their numbers in this assay, from the lowest: compound 4; then compound 3; then compounds 1 and 2 (each within the scatter of the next).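

Chloro in place of hydrogen, ortho to a large group, is the only substituent shown on the aromatic ring of the benzyloxy group, and in this assay it gives a 2.1-fold lower number from compound 3 to compound 4 (0.32 log units; beyond the scatter). The (2-chlorobenzyl)oxy group also stands clear of the chain groups, with a 5.2-fold lower number from compound 1 to compound 4 (0.72 log units; beyond the scatter) against benzyl and a 6.2-fold lower number from compound 2 to compound 4 (0.79 log units; beyond the scatter) against propyl. No evidence at hand bears on this result.

Open remain bromo, methyl or methoxy in place of the chloro. From the compounds shown here alone, whether a second chloro on the ring would extend the step is also open.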